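The source may hold more compounds than are shown below. What is called first, only, known or untested is meant among the compounds shown, and "the series" means these compounds.

Of the compounds shown here, two that share a core have been tested in a functional assay on HeLa cells (Homo sapiens) for cytotoxicity, read by MTT assay, with a stated time of 72 h, tested at 30 uM; a higher number here means more inhibition of growth at the concentration tested, a lower number less inhibition of growth. Compound 2 `Cc1cccc(/C(N)=N/NC(=S)N2CCSCC2)n1` gives 85.3%, the higher of the two values. Compound 1 `Cc1ccnc(/C(N)=N/NC(=S)N2CCOCC2)c1` gives 45.2% in this assay, and the gap between it and compound 2 lies well beyond the usual scatter. Since compound 1 differs from compound 2 in more than one place, the two values show only how far apart they sit, not which part of the structure accounts for it.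

Compound 3 `Cc1cccc(/C(N)=N/NC(=S)N2CCCCC2)n1` has not yet been measured. It differs from compound 2 in a single place: piperidin-1-yl in place of thiomorpholin-4-yl on a thiocarbonyl carbon. Going by the values given here, no pair of measured compounds shows what this kind of exchange does here, so any expectation rests on compound 2 alone. A small change is expected, a number 7.3 percentage points lower from compound 2 to compound 3 (within the scatter), which stays within the usual scatter. Compound 3 is estimated at 78%, with a plausible range from 55% to 95%.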

Compound 3, percent growth inhibition at one concentration: 83.5%
Compound 3: the middle estimate sits 5.5 percentage points below what was measured, within the range that was stated.
By their numbers in this assay, from the lowest: compound 1; then compounds 3 and 2 (each within the scatter of the next).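

In this assay, exchanging the ring on the thiocarbonyl carbon gives a number 1.8 percentage points lower from compound 2 to compound 3 (within the scatter), so the two compounds cannot be told apart. Going by these compounds alone, this is the first direct reading of this position: with the rest of the structure held the same, the sulfur of thiomorpholin-4-yl is not required for this level of growth inhibition, since piperidin-1-yl, with carbon in its place, reads alike at the single concentration tested. No measurement at hand explains why these two rings read alike.

Still open, from the compounds shown here alone, is whether the same holds for other groups at this position, such as piperazin-1-yl with its second ring nitrogen or an open-chain dimethylamino group. The morpholin-4-yl ring of compound 1 also stays unresolved, as compound 1 differs from compound 2 elsewhere too.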